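The source may hold more compounds than are shown below. What is called first, only, known or untested is meant among the compounds shown, and "the series" means these compounds.

In a functional assay on UO-31 cells (Homo sapiens) for inhibition, read by sulforhodamine B assay, with a stated time of 48 h (on this read-out lower numbers stand for stronger inhibition of growth and higher numbers for weaker inhibition of growth), compound 1 `O=C(Cc1csc2nc(-c3ccc(Br)cc3)cn12)N/N=C/c1ccccc1` gives > 100000 nM, which is a limit. Compound 2 `O=C(Cc1csc2nc(-c3ccc(Br)cc3)cn12)N/N=C/c1ccc(O)cc1` gives > 100000 nM, again a limit. Compound 3 `COc1cccc(OC)c1/C=N/NC(=O)Cc1csc2nc(-c3ccc(Br)cc3)cn12` gives > 100000 nM, also a limit, so it carries no number. Compound 4 `O=C(Cc1csc2nc(-c3ccc(Br)cc3)cn12)N/N=C/c1ccc(Cl)cc1Cl` has 2,4-dichlorophenyl in place of 2,6-dimethoxyphenyl on a carbon with a double bond to nitrogen. Two measured changes at that carbon bear on this, a step that the two limits leave unreadable from compound 1 to compound 3 and a step that the two limits leave unreadable from compound 2 to compound 3, and neither has a readable size. The same holds for a step that the two limits leave unreadable from compound 1 to compound 2. No clear shift in this assay is expected because of the limit of > 100000 nM in this assay, at which 3 of the 3 values shown sit. The expected step is a number no higher from compound 3 to compound 4 (the limit leaves the size open), with no direction expected beyond the scatter. For compound 4 the estimated value is 100000 nM, with an expected range from 30000 nM to 100000 nM.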

Compound 4, concentration for total growth inhibition: > 100000 nM
Compound 4: a limit, no number; the forecaster's own chance of this, stated with the estimate: 75%; the middle value sits exactly at the limit.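

Compound 4, like compounds 1, 2 and 3, stands only as a limit in this assay, so no step among these compounds can be read: the limit of > 100000 nM in this assay, at which 4 of the 4 values shown sit.

From the compounds shown here alone, whether any group on the carbon with a double bond to nitrogen changes growth inhibition remains open.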